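A few compounds are considered here, and "the series" means these few. Any claim that something is new, unique, unknown or untested is made for them only; others in the source may bear on it.

Measured compounds in a functional assay on isolated protein for agonist activity at Glucose-dependent insulinotropic receptor (Homo sapiens), read by HTRF and cAMP accumulation; on this read-out higher numbers stand for larger maximal responses and lower numbers for smaller maximal responses:
compound 1 `CC(C)(C)OC(=O)N1CCC(O[C@H]2CC[C@@H](Oc3ccc(S(C)(=O)=O)cc3)CC2)CC1` — 120%
compound 2 `Cc1nc(O[C@H]2CC[C@H](OC3CCN(C(=O)OC(C)(C)C)CC3)CC2)ccc1C(=O)N(C)C` — 121%
compound 3 `C[C@H](CF)OC(=O)N1CCC(O[C@H]2CC[C@H](Oc3cnc(S(C)(=O)=O)cn3)CC2)CC1` — 108%

All three compounds share a core and differ at the carbamate end and at the aryl ether end. Compound 3 stands lowest of the three on this assay. Its nearest neighbour in value is compound 1, which lies higher by an amount beyond the usual scatter, and compound 2 lies higher still, also beyond the scatter. No pair among these three differs in only one place, so no single structural step has a measured size here.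

Compound 4 `CS(=O)(=O)c1cnc(O[C@H]2CC[C@H](OC3CCN(C(=O)Oc4ccccc4)CC3)CC2)cn1` is the next compound to be measured. It is derived from compound 3 by a change at the carbamate end: phenyl in place of 1-(fluoromethyl)ethyl on an oxygen next to a carbonyl group.

Because compound 3 gives 108% and the whole set sits in a narrow band of full responses, compound 4 is expected to remain in that band; the step of a number 6 percentage points higher from compound 3 to compound 4 (within the scatter) is expected to be small, if anything upward, and possibly within the scatter. The estimate for compound 4 is 114%, with a likely range from 100% to 128%.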

Compound 4, largest response reached (Emax), in percent of the reference or control that the assay uses: 116%
The estimate for compound 4 lay 2 percentage points below the measured number, and the stated range covers the measured number.
By their numbers in this assay, from the lowest: compounds 3, 4, 1 and 2 (each within the scatter of the next, the first and the last beyond it).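

At the carbamate end, phenyl in place of 1-(fluoromethyl)ethyl on an oxygen next to a carbonyl group gives, in this assay, a number 8 percentage points higher from compound 3 to compound 4 (within the scatter). Going by these compounds alone, this is the first single-place step, and it shows that a six-membered aromatic ring of carbon only can enter at this oxygen and the defined stereocentre can leave without the maximal response moving beyond the scatter. Nothing available explains this step.

The compounds shown leave open how a benzyl group, a chlorophenyl group or a longer alkyl chain on the same oxygen would read out. They also leave open whether the phenyl change gives a similar step with the aryl ether ends of compound 1 and compound 2.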